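Moving a Methoxy Group on a Carbonyl Carbon

The compounds below may be only part of what the source reports. "The series", "measured", "known", "first", "only" and "open" are said of these compounds alone.

Compound 1 `Cn1cc(-c2nc3ccccc3n2C(=O)c2ccccc2)c2ccccc21`: 42300 nM
Compound 2 `COc1ccccc1C(=O)n1c(-c2cn(C)c3ccccc23)nc2ccccc21`: 31800 nM

In a functional assay on HepG2 cells (Homo sapiens) for inhibition, read by MTT assay, with a stated time of 24 h (a lower number here means a stronger inhibitor of growth, a higher number a weaker inhibitor of growth), compound 2 gives 31800 nM. That value lies within the scatter of compound 1 at 42300 nM, so the two cannot be ranked. Compound 3 `COc1cccc(C(=O)n2c(-c3cn(C)c4ccccc34)nc3ccccc32)c1` carries 3-methoxyphenyl in place of 2-methoxyphenyl on a carbonyl carbon. Among the compounds with values here, the one measured step that bears on this change is a 1.3-fold lower number from compound 1 to compound 2 (0.12 log units; within the scatter), with methoxy in place of hydrogen on an aromatic carbon, and it lies within the scatter. Within the data shown here, no compound with 3-methoxyphenyl has been measured, so this evidence is only indirect. A step beyond the scatter is therefore not expected in this assay, in either direction. The estimated step is a 1.1-fold higher number from compound 2 to compound 3 (0.03 log units; within the scatter). Compound 3 is expected at 34000 nM, with an estimated range of 15000 nM to 75000 nM.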

Compound 3, concentration for 50% growth inhibition: 13600 nM
Estimate against measurement, compound 3: 2.5-fold (0.40 log units) above, outside the stated range (below it).
By their numbers in this assay, from the lowest: compound 3; then compounds 2 and 1 (each within the scatter of the next).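

Moving the methoxy group from 2-methoxyphenyl to 3-methoxyphenyl on a carbonyl carbon, with the same atoms joined differently, shifts the number in this assay by more than the scatter (a 2.3-fold lower number from compound 2 to compound 3 (0.37 log units; beyond the scatter)). Adding methoxy as 2-methoxyphenyl had not separated compound 2 from compound 1, whereas compound 3 does stand apart from compound 1 (a 3.1-fold lower number from compound 1 to compound 3 (0.49 log units; beyond the scatter)), so in this series the place of the methoxy group counts and not merely its presence. No data shown here explain the difference.

The compounds shown leave open whether this shift belongs to methoxy itself or would also appear with another group in the same place, such as an amine, a carboxylic acid or a longer chain like ethoxy. They also leave open whether the order of the three compounds holds in other cells.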